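The source may report more compounds than this note shows. Statements on the series, on what has been measured and on what is new or still open speak of the compounds shown alone.

Measured so far in a physicochemical assay for solubility; a lower number here means a less soluble compound, a higher number a more soluble compound:
Compound 1 `COCCOc1ccc2c(c1)C=CN(C)C(=O)[C@@H]2C`: >= 128 ug/mL, a limit
Compound 2 `C[C@H]1C(=O)N(C)C=Cc2cc(CN3CCCC3)ccc21`: >= 97 ug/mL, a limit

Compound 2 has no exact reading: in this assay compound 2 gives >= 97 ug/mL, which is a limit of the assay and not a number. Among the compounds with values here, the only other value, that of compound 1, is a limit too.

The next compound is compound 3 `C[C@H]1C(=O)N(C)C=Cc2cc(C(CO)CO)ccc21`, in which 2-hydroxy-1-(hydroxymethyl)ethyl takes the place of (pyrrolidin-1-yl)methyl on an aromatic carbon: 2-hydroxy-1-(hydroxymethyl)ethyl in place of (pyrrolidin-1-yl)methyl on an aromatic carbon. The rest of the structure is unchanged.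

Within the data shown here, only one measured step bears on this change, and it also swaps a group on an aromatic carbon: a step that the two limits leave unreadable from compound 1 to compound 2. Both of its ends are limits, so it offers no size to carry over and no direction to follow. All that remains is the level at which both measured compounds sit, so no clear rise or fall can be predicted.

The expected change is small and uncertain: a step that the limit leaves unreadable from compound 2 to compound 3.

For compound 3 the estimated value is 110 ug/mL, with an expected range of 50 ug/mL to 200 ug/mL.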

Compound 3, solubility: >= 209 ug/mL
Compound 3 was reported as a limit; the forecaster's own chance of this, stated with the estimate: 60%; middle value at least 1.9-fold (0.27 log units) from the limit.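

Within the data shown here, compound 1, compound 2 and compound 3 all carry limits in this assay rather than exact numbers, so no step among them can be read, in size or in direction. The compounds shown leave open where the true solubility of each one lies, and whether changing the group on the aromatic carbon alters it at all.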